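The compounds below may be only part of what the source reports. "The series", "measured", "known", "first", "only" and "open" are said of these compounds alone.

Working notes on the series. Three members have been measured in a functional assay on IGROV-1 cells (Homo sapiens) for cytotoxicity, read by sulforhodamine B assay, with a stated time of 48 h; on this read-out lower numbers stand for stronger inhibition of growth and higher numbers for weaker inhibition of growth. Compound 1, `CC1=C(C(=O)Nc2ccc(F)c(Cl)c2)C(c2ccccc2Cl)NC(=S)N1`, gives 17800 nM. Compound 2, `CC1=C(C(=O)Nc2ccc(F)c(Cl)c2)C(c2cccc(Oc3ccccc3)c2)NC(=S)N1`, gives 10700 nM, and compound 3, `CC1=C(C(=O)Nc2ccc(Cl)c(Cl)c2)C(c2cccc(Oc3ccccc3)c2)NC(=S)N1`, gives 7760 nM. The difference between the core of compound 1 and the core of compound 2 is not broken down here. Compound 3 differs from compound 2 by chloro in place of fluoro on an aromatic carbon, and this step gave a 1.4-fold lower number from compound 2 to compound 3 (0.14 log units; within the scatter). Of the three measured numbers, compound 1 has the highest; compound 2 lies within the scatter of it, while compound 3 lies beyond it.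

Compound 4, `CC1=C(C(=O)Nc2ccc(Cl)c(Cl)c2)C(c2ccccc2Cl)NC(=S)N1`, is still to be measured. For the measured compounds named here, it differs from compound 1 by chloro in place of fluoro on an aromatic carbon, the same change as the one made from compound 2 to compound 3, at the same place around the ring. The expected step is modest: because the same change gave a 1.4-fold lower number from compound 2 to compound 3 (0.14 log units; within the scatter), the step to compound 4 is estimated at a 1.4-fold lower number from compound 1 to compound 4 (0.15 log units; within the scatter). On this basis compound 4 is expected to give 12500 nM in this assay, with the likely range from 6000 nM to 25000 nM.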

Compound 4, concentration for 50% growth inhibition: 15800 nM
For compound 4 the middle estimate is 1.3-fold (0.10 log units) below the measured one, within the range that was stated.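

On the core of compound 1, chloro in place of fluoro gives a 1.1-fold lower number from compound 1 to compound 4 (0.05 log units; within the scatter) in this assay. The step on this core and the step on the core of compound 2 cannot be told apart: the same change on two cores in this assay, a 1.4-fold lower number (0.14 log units; within the scatter) from compound 2 to compound 3 and a 1.1-fold lower number (0.05 log units; within the scatter) from compound 1 to compound 4, 1.2-fold (0.09 log units) apart, within the scatter of two such steps. This shows that the change behaves alike on these two cores, with a step too small to read on either, but it does not show that chloro truly lowers the number on either core, and two cores say nothing about how the change carries to any other core.

Still open, as far as these compounds go, is whether another group in this place, such as a methoxy group, a nitrile or an amine, would give a step beyond the scatter in this assay. Also open, from the compounds shown here alone, is whether the step stays this small on a core with a carbonyl in place of the thiocarbonyl.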